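Methyl for fluoro on the benzyl ring of compound 2

The source may hold more compounds than are shown below. What is called first, only, known or untested is meant among the compounds shown, and "the series" means these compounds.

Compound 1 `NC(=O)N1CCN(C(=S)SCc2cn(Cc3ccccc3F)nn2)CC1`: in a functional assay on SMMC-7721 cells (Homo sapiens) for cytotoxicity, read by MTT assay, with a stated time of 72 h (on this read-out higher numbers stand for weaker inhibition and lower numbers for stronger inhibition), compound 1 gives only a limit, > 128000 nM.
Compound 2 `NC(=O)N1CCN(C(=S)SCc2cn(Cc3ccc(F)cc3)nn2)CC1`: compound 2 gives only a limit, > 128000 nM.
Compound 3 `O=C(NC1CCCCC1)N1CCN(C(=S)SCc2cn(Cc3ccc(F)cc3)nn2)CC1`: compound 3 gives only a limit, > 128000 nM.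

Compound 2 therefore stands at the limit, as do the other two measured compounds (the limit of > 128000 nM in this assay, at which 3 of the 3 values shown sit). The two measured steps, a step that the two limits leave unreadable from compound 1 to compound 2 and a step that the two limits leave unreadable from compound 2 to compound 3, cannot be sized. Compound 4 `Cc1ccc(Cn2cc(CSC(=S)N3CCN(C(N)=O)CC3)nn2)cc1` differs from compound 2 by methyl in place of fluoro on an aromatic carbon. Within the data shown here, no measured step touches this change, and the measured series gives no readable step in this assay at all. Compound 4 is expected to remain at the limit, with an estimated value of 200000 nM, ranging from 90000 nM to 600000 nM. The step that the limit leaves unreadable from compound 2 to compound 4 is thus expected to be unreadable rather than a measured shift.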

Compound 4, half-maximal inhibitory concentration: > 128000 nM
Compound 4 ended at the assay's limit; the forecaster's own chance of this, stated with the estimate: 80%; the middle value is on the limit's open side.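

No step among compound 1, compound 2, compound 3 and compound 4 can be read in this assay; all four sit at the limit: the limit of > 128000 nM in this assay, at which 4 of the 4 values shown sit.

The compounds shown leave open which structural change, if any, would give a measurable value in this assay.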